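Alkyl change on the ring nitrogen: expectation for compound 4

The source may hold more compounds than are shown below. What is called first, only, known or untested is meant among the compounds shown, and "the series" means these compounds.

Measured compounds:
compound 1 `CCC(C)n1cnc2c(NCc3ccc(C(=O)Nc4ccccc4N)cc3)nc(Cl)nc21` gives 47.3% in a functional assay on NCI-H460 cells (Homo sapiens) for antiproliferative activity, read by CCK-8 assay, with a stated time of 72 h, tested at 2 uM; on this read-out lower numbers stand for a weaker effect and higher numbers for a stronger effect at the one concentration tested
compound 2 `CC(C)n1cnc2c(NCc3ccc(C(=O)Nc4ccccc4N)cc3)nc(Cl)nc21` gives 54.2% in this assay
compound 3 `Nc1ccccc1NC(=O)/C=C/c1ccc(Cn2cnc3c(NC4CCCCC4)nc(Cl)nc32)cc1` gives 8.09% in this assay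

Compound 2 holds the highest of the three numbers; compound 1 sits within the scatter of it, while compound 3 lies well beyond. Compound 4 `CCCn1cnc2c(NCc3ccc(C(=O)Nc4ccccc4N)cc3)nc(Cl)nc21` differs from compound 2 by propyl in place of isopropyl on an aromatic nitrogen. Among the measured compounds shown here, the one measured step that bears on this is the alkyl change at the same ring nitrogen, a number 6.9 percentage points higher from compound 1 to compound 2 (within the scatter), which stayed within the scatter. A second reshuffling of the same three carbons on that nitrogen is therefore expected to give no step beyond the scatter, with an estimated step of a number 4.2 percentage points lower from compound 2 to compound 4 (within the scatter). Compound 4 is accordingly estimated at 50% in this assay, within a range of 35% to 65%.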

Compound 4, a percentage reported as inhibition, at one concentration (the size of the read-out at that concentration, not a potency): 31%
For compound 4 the middle estimate is 19 percentage points above the measured one; measured number below the stated range.
By their numbers in this assay, from the lowest: compound 3; then compound 4; then compounds 1 and 2 (each within the scatter of the next).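

In this assay this ring nitrogen responds to how the alkyl carbons are joined and not only to their count: propyl in place of isopropyl gives a number 23.2 percentage points lower from compound 2 to compound 4 (beyond the scatter), and hydrogen in place of methyl on the chain carbon bound to the nitrogen gives a number 16.3 percentage points lower from compound 1 to compound 4 (beyond the scatter). Among these three compounds, the two branched groups stay within the scatter of each other, while the unbranched propyl falls beyond the scatter of both. No measured evidence accounts for this drop. On these data alone, whether tert-butyl or cyclopentyl on the same nitrogen keeps the higher numbers remains open, as does whether a longer unbranched chain such as butyl follows propyl.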